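Extending methylamino to ethylamino

The source may hold more compounds than are shown below. What is called first, only, known or untested is meant among the compounds shown, and "the series" means these compounds.

In a functional assay on the whole organism with Rattus norvegicus as the target (on this read-out lower numbers stand for an effect already at smaller amounts and higher numbers for an effect only at larger amounts of compound), compound 1 `CCOC(=O)C(=O)Nc1cccc(OC)c1C#N` carries a methoxy group and gives 55.5 mg/kg as its dose. Compound 2 `CCOC(=O)C(=O)Nc1cccc(NC)c1C#N` has methylamino instead and gives 0.1 mg/kg as the lower of the two numbers. Compound 3 `CCNc1cccc(NC(=O)C(=O)OCC)c1C#N` differs from compound 2 by a single change methyl in place of hydrogen on a saturated chain carbon bound to a nitrogen on an aromatic ring in which methyl takes the place of hydrogen on a saturated chain carbon bound to a nitrogen on an aromatic ring, turning methylamino into ethylamino. Going by the values given here, the only measured step bearing on this is a 560-fold lower number from compound 1 to compound 2 (2.74 log units; beyond the scatter) and it is large, yet it replaced the atom bound to the ring. The new change keeps that nitrogen and only extends its chain, so that step is a weak guide. In this assay a far smaller shift is expected, with a 3.0-fold higher number from compound 2 to compound 3 (0.48 log units; beyond the scatter) as the estimated step toward a somewhat higher number. Compound 3 is estimated at 0.3 mg/kg with a range from 0.05 mg/kg to 3 mg/kg overall.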

Compound 3, dose for half-maximal effect: 0.03 mg/kg
Beside the measured number, compound 3's estimate is 10-fold (1.00 log units) above it; measured number outside the range, below it.
By their numbers in this assay, from the lowest: compound 3; then compound 2; then compound 1.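

In this assay, the gain seen with methylamino is not lost when its chain grows: methyl in place of hydrogen on the saturated chain carbon gives a 3.3-fold lower number from compound 2 to compound 3 (0.52 log units; beyond the scatter), a modest step but beyond the usual scatter. Measured against the methoxy group, ethylamino gives a 1900-fold lower number from compound 1 to compound 3 (3.27 log units; beyond the scatter), so this position still responds after the nitrogen is in place, and the size of the chain on that nitrogen matters as well as the atom bound to the ring. No measurement shown here accounts for the difference between ethylamino and methylamino.

With only these two amino groups, no trend with chain length can be drawn. A longer chain such as propylamino or butylamino could continue the drop or reverse it, and dimethylamino would show what happens when the remaining hydrogen on that nitrogen is replaced.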